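Compound 3 to compound 4: chloro in place of methoxy

The compounds below may be only part of what the source reports. "The series", "measured", "known", "first", "only" and "open" are said of these compounds alone.

In a functional assay on MGC-803 cells (Homo sapiens) for inhibition, read by sulforhodamine B assay (on this read-out higher numbers stand for weaker inhibition and lower numbers for stronger inhibition), compound 1 `O=C1C=C(Nc2ccccc2F)C(=O)c2c1nc1n2[C@H]2OC[C@@H](O)[C@H]2OC1` gives 2080 nM and compound 2 `O=C1C=C(Nc2cccc(F)c2)C(=O)c2c1nc1n2[C@H]2OC[C@@H](O)[C@H]2OC1` gives 2180 nM while compound 3 `COc1cccc(NC2=CC(=O)c3nc4n(c3C2=O)[C@H]2OC[C@@H](O)[C@H]2OC4)c1` gives 1780 nM within the scatter of both. Compound 4 `O=C1C=C(Nc2cccc(Cl)c2)C(=O)c2c1nc1n2[C@H]2OC[C@@H](O)[C@H]2OC1` differs from compound 3 by chloro in place of methoxy on an aromatic carbon with chloro in place of methoxy on an aromatic carbon, meta to a large group. The closest measured exchange is a 1.2-fold lower number from compound 2 to compound 3 (0.09 log units; within the scatter) with methoxy in place of fluoro on an aromatic carbon. The steps of a 1.0-fold higher number from compound 1 to compound 2 (0.02 log units; within the scatter) and a 1.2-fold lower number from compound 1 to compound 3 (0.07 log units; within the scatter) also stay within the scatter. No step beyond the scatter is therefore expected in this assay for this exchange. The estimated change is a 1.1-fold higher number from compound 3 to compound 4 (0.03 log units; within the scatter) and so stays inside the scatter. Compound 4 is expected at 1900 nM within a range of 1050 nM to 3400 nM in this estimate.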

Compound 4, half-maximal inhibitory concentration: 1770 nM
Estimate against measurement, compound 4: 1.1-fold (0.03 log units) above; the range from low to high includes it.
By their numbers in this assay, from the lowest: compounds 4, 3, 1 and 2 (each within the scatter of the next).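

In this assay, chloro in place of methoxy gives a 1.0-fold lower number from compound 3 to compound 4 (0.00 log units; within the scatter), so a third kind of substituent on this aromatic carbon still leaves the number unmoved. Against the two fluorinated compounds, the changes give a 1.2-fold lower number from compound 2 to compound 4 (0.09 log units; within the scatter) and a 1.2-fold lower number from compound 1 to compound 4 (0.07 log units; within the scatter), which places all four compounds within the scatter and gives them no meaningful order. No supporting data bear on why this position tolerates these exchanges. On these data alone, it remains open whether an amine, a carboxylic acid or a longer chain on this aromatic carbon would produce a step beyond the scatter.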